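Acetamide tail variants on the shared core

The compounds below may be only part of what the source reports. "The series", "measured", "known", "first", "only" and "open" are said of these compounds alone.

Measured compounds in a functional assay on MCF7 cells (Homo sapiens) for cytotoxicity, read by MTT assay, with a stated time of 24 h, tested at 32 ug/mL; a lower number here means a weaker effect, a higher number a stronger effect of the compound at the concentration tested:
compound 1, `Cn1c(-c2ccc(NC(=O)CSc3nc4ccccc4s3)cc2)nc(-c2ccccc2)c1-c1ccccc1`, 59%
compound 2, `Cn1c(-c2ccc(NC(=O)CSC3=NCCS3)cc2)nc(-c2ccccc2)c1-c1ccccc1`, 52.5%
compound 3, `Cn1ccnc1SCC(=O)Nc1ccc(-c2nc(-c3ccccc3)c(-c3ccccc3)n2C)cc1`, 43.4%

Compound 3 has the lowest of the three numbers in this assay. Its nearest neighbour is compound 2, and that gap, a number 9.1 percentage points lower from compound 2 to compound 3 (within the scatter), is within the scatter. Against compound 1 the difference is a number 15.6 percentage points lower from compound 1 to compound 3 (beyond the scatter), which is beyond the scatter and modest. The step of a number 6.5 percentage points lower from compound 1 to compound 2 (within the scatter) is within the scatter.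

Compound 4, `Cn1c(-c2ccc(NC(=O)CN3CCN(c4ccccc4)CC3)cc2)nc(-c2ccccc2)c1-c1ccccc1`, is not yet measured. It differs from compound 3 by 4-phenylpiperazin-1-yl in place of (1-methyl-1H-imidazol-2-yl)sulfanyl on a saturated chain carbon bound to a carbonyl carbon. Among the compounds with values here, no measured step swaps the sulfanyl link itself; the three measured steps change only the ring attached to the sulfur. The only clear direction comes from the step from compound 1 to compound 3, where the larger tail holding a carbon-only aromatic ring sat higher; the tail entering in compound 4 also carries such a ring, so a rise of comparable size back toward the value of compound 1 is the working expectation, with a wide range given that the link itself is new to the series.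

Compound 4 is therefore expected at 52%, between 32% and 72%, an estimated step of a number 8.6 percentage points higher from compound 3 to compound 4 (within the scatter).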

Compound 4, a percentage reported as activity, at one concentration (the size of the read-out at that concentration, not a potency): 63.6%
Compound 4: middle estimate off by 11.6 percentage points, on the low side; measured number inside the range.
By their numbers in this assay, from the lowest: compounds 3, 2, 1 and 4 (each within the scatter of the next, the first and the last beyond it).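

With 4-phenylpiperazin-1-yl on the saturated chain carbon bound to a carbonyl carbon, the read-out in this assay does not depend on a sulfanyl link: this sulfur-free tail gives a number 20.2 percentage points higher from compound 3 to compound 4 (beyond the scatter) against (1-methyl-1H-imidazol-2-yl)sulfanyl and a number 11.1 percentage points higher from compound 2 to compound 4 (beyond the scatter) against the non-aromatic sulfanyl tail. Against (1,3-benzothiazol-2-yl)sulfanyl the same position gives a number 4.6 percentage points higher from compound 1 to compound 4 (within the scatter) and thus no separation, so two tails with a six-membered aromatic ring of carbon only, one joined through sulfur and one through a non-aromatic ring, cannot be told apart here; compound 2, without such a ring, goes against any simple rule on that ring, as its step from compound 1 also lies within the scatter. Nothing available explains why the tails differ.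

Still open, on these data alone, is whether the phenyl ring or the piperazine ring carries the value of the new tail, which a 4-methylpiperazin-1-yl, morpholin-4-yl or 4-phenylpiperidin-1-yl group on the same carbon would help to separate. A longer chain in place of the single chain carbon is also untested in the compounds shown, and a single-concentration read-out gives no potency for any of these tails.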